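The compounds below may be only part of what the source reports. "The series", "measured", "known", "first", "only" and "open" are said of these compounds alone.

Measured so far in a functional assay on MCF7 cells (Homo sapiens) for cytotoxicity, read by MTT assay, with a stated time of 72 h; on this read-out lower numbers stand for stronger inhibition and higher numbers for weaker inhibition:

compound 1 `FC(F)(F)c1ccc(CSc2nc(Nc3ccccc3Cl)c3ccccc3n2)cc1` — gives only the limit > 50000 nM
compound 2 `FC(F)(F)c1ccc(CSc2nc(Nc3cccc(C(F)(F)F)c3)c3ccccc3n2)cc1` — gives 15300 nM

Compound 1 stands at the edge of what this assay reports: its value is a limit and not a number, so compound 1 has no fixed position on the scale. Among the compounds with values here, the one measured step is an at least 3.2-fold lower number from compound 1 to compound 2 (0.51 log units; beyond the scatter), and it can only be read as a bound because the limit of > 50000 nM in this assay, at which 1 of the 2 values shown sits, leaves the starting point open.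

Compound 3 `COc1cc(Nc2nc(SCc3ccc(C(F)(F)F)cc3)nc3ccccc23)cc(OC)c1` is not yet measured. It differs from compound 1 by 3,5-dimethoxyphenyl in place of 2-chlorophenyl on a nitrogen on an aromatic ring. Within the data shown here, the step from compound 1 to compound 2 is the only measured step that bears on this change, since it alters the same group on the same nitrogen; there 3-(trifluoromethyl)phenyl entered, here 3,5-dimethoxyphenyl does, so the comparison is only partial. A lower number than the limit of compound 1 is nonetheless the expectation, with a fair chance that the assay again returns only a limit.

Compound 3 is therefore estimated at 22000 nM in this assay, within a range from 7000 nM to 60000 nM. The expected step is an at least 2.2-fold lower number from compound 1 to compound 3 (0.35 log units; beyond the scatter).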

Compound 3, half-maximal inhibitory concentration: 6990 nM
For compound 3 the middle estimate is 3.1-fold (0.50 log units) above the measured one; the measured number lies below the stated range.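

In this assay, the group on this nitrogen now has a step with a number at both ends: a 2.2-fold lower number from compound 2 to compound 3 (0.34 log units; beyond the scatter). This shows that exchanging one substituted phenyl group for another at this position still moves the read-out beyond the scatter, with 3,5-dimethoxyphenyl giving the lower number of the two. Compound 1 remains a limit of the assay and not a number, so the change from 2-chlorophenyl can be read only as a bound, an at least 7.1-fold lower number from compound 1 to compound 3 (0.85 log units; beyond the scatter), and the limit applies to that step as well: the limit of > 50000 nM in this assay, at which 1 of the 3 values shown sits.

The compounds shown do not separate the effect of one methoxy group from that of two, and they do not show whether an amine or a carboxylic acid on the same phenyl ring, or a cyclohexyl group in its place, would lower the number further. The rest of the structure is the same in compound 1, compound 2 and compound 3, so nothing here tells how the 4-(trifluoromethyl)benzyl group on sulfur or the shared core contributes to the read-out in this assay.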